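Swapping the Ester Aryl Substituent: Nitro to Methyl

This account rests on a few compounds, and the source may have more. Where it says the series, first, only, none or still open, it means among the compounds named here.

Three esters on a shared core have been measured in a functional assay on J774.A1 cells (Mus musculus) for inhibition, read by ELISA, with a stated time of 24 h, tested at 20 uM; on this read-out higher numbers stand for more inhibition at the one concentration tested (going by the name of the read-out) and lower numbers for less inhibition. Compound 1 `C=C1CC[C@@H]2[C@](C)(CO)[C@H](O)CC[C@@]2(C)[C@@H]1CC(OC(C)=O)C1=CCOC1=O` gives 95.1%, compound 2 `C=C1CC[C@@H]2[C@](C)(CO)[C@H](O)CC[C@@]2(C)[C@@H]1CC(OC(=O)CCCCC)C1=CCOC1=O` gives 82.9%, and compound 3 `C=C1CC[C@@H]2[C@](C)(CO)[C@H](O)CC[C@@]2(C)[C@@H]1CC(OC(=O)c1ccc([N+](=O)[O-])cc1)C1=CCOC1=O` gives 58.6%. Compound 3 stands lowest of the three, with a number 36.5 percentage points lower from compound 1 to compound 3 (beyond the scatter) and a number 24.3 percentage points lower from compound 2 to compound 3 (beyond the scatter). Compound 4 `C=C1CC[C@@H]2[C@](C)(CO)[C@H](O)CC[C@@]2(C)[C@@H]1CC(OC(=O)c1ccc(C)cc1)C1=CCOC1=O` differs from compound 3 by methyl in place of nitro on an aromatic carbon. Going by the values given here, no measured step changes a group on the aromatic ring itself; the two steps that bear on compound 4 are those that brought in the 4-nitrophenyl in place of alkyl groups, one large and one modest, both downward. Whether taking the nitro away recovers part of that loss is uncertain, so only a modest upward step a number 9.4 percentage points higher from compound 3 to compound 4 (within the scatter) is expected. Compound 4 is therefore estimated at 68%, within 50% to 85%.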

Compound 4, a percentage reported as inhibition, at one concentration (the size of the read-out at that concentration, not a potency): 128%
Compound 4: middle estimate off by 60 percentage points, on the low side, outside the stated range (above it).
By their numbers in this assay, from the lowest: compound 3; then compound 2; then compound 1; then compound 4.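

The aromatic ring on the ester carbonyl does not by itself lower the number: methyl in place of nitro gives a number 69.4 percentage points higher from compound 3 to compound 4 (beyond the scatter) and shows that the group on that ring decides the outcome. The 4-methylphenyl ester also rises above both alkyl esters, with a number 45.1 percentage points higher from compound 2 to compound 4 (beyond the scatter) and with a number 32.9 percentage points higher from compound 1 to compound 4 (beyond the scatter) as well, which reverses the downward direction seen with the 4-nitrophenyl ester. Nothing measured here accounts for the difference between methyl and nitro at this ring carbon.

The compounds shown leave open where a plain phenyl ester would fall. They also leave open whether an amine, a methoxy group or a chlorine at this ring carbon would sit nearer compound 3 or compound 4.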